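The source may hold more compounds than are shown below. What is called first, only, known or untested is meant among the compounds shown, and "the series" means these compounds.

Compound 1 `CC(C)(C)c1cc(=O)c2ccc(O)cc2o1` is reported in an assay on isolated protein for inhibition of Polyunsaturated fatty acid lipoxygenase ALOX15 (Homo sapiens) (a higher number here means a weaker inhibitor, a lower number a stronger inhibitor), at > 100000 nM, which is a limit of the assay.
Compound 2 `CCCCCc1cc(=O)c2ccc(O)cc2o1` sits at > 100000 nM, also a limit.
Compound 3 `CC(C)Cc1oc2ccccc2c(=O)c1O` sits at > 100000 nM, again a limit.

Compound 3 therefore stands at the limit of > 100000 nM in this assay, at which 3 of the 3 values shown sit, with no number to place it. The change to compound 4 `CCCCCc1oc2ccccc2c(=O)c1O` is butyl in place of isopropyl on a saturated chain carbon bound to an aromatic carbon. Among the compounds with values here, the only measured step, a step that the two limits leave unreadable from compound 1 to compound 2, runs between two limits and gives no size. Nothing measured says which way compound 4 should move. Within the data shown here, with every value so far a limit, the expectation is that compound 4 again comes out as a limit rather than a number. The step that the limit leaves unreadable from compound 3 to compound 4 is estimated as no change. For compound 4 the estimate in this assay is 150000 nM, between 30000 nM and 1000000 nM.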

Compound 4, half-maximal inhibitory concentration: > 100000 nM
Compound 4 gave a limit, no number (the forecaster's own chance of this, stated with the estimate: 80%); the middle value does not contradict the limit.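

Within the data shown here, compound 3 and compound 4 both stand as limits in this assay, so no step between them can be read. The compounds shown leave open whether any change to them would give a number rather than a limit.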